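Replacing the pyrazole on a shared core: an expectation

This account rests on a few compounds, and the source may have more. Where it says the series, first, only, none or still open, it means among the compounds named here.

Within the data shown here, compound 3 `O=C(O)Cc1sc(C(c2ccc(F)cc2)c2ccc(F)cc2)nc1-c1cn[nH]c1` gives 80% in an in vitro functional assay on HEK285-7 cells for antagonist activity at prostaglandin D2 receptor 2 (Homo sapiens), read by BRET and beta-arrestin recruitment (a lower number here means a smaller maximal response, a higher number a larger maximal response), the highest of the three numbers measured so far. Compound 2 `NS(=O)(=O)c1cccc(-c2nc(C(c3ccc(F)cc3)c3ccc(F)cc3)sc2CC(=O)O)c1` gives 55%, and the step of a number 25 percentage points higher from compound 2 to compound 3 (beyond the scatter) lies beyond the scatter. Compound 1 `N#Cc1ccc(-c2nc(C(c3ccc(F)cc3)c3ccc(F)cc3)sc2CC(=O)O)cc1` gives 30%, and the step of a number 50 percentage points higher from compound 1 to compound 3 (beyond the scatter) is the largest in the set, with a number 25 percentage points higher from compound 1 to compound 2 (beyond the scatter) connecting the two lower numbers.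

Compound 4 `Cc1cc(-c2nc(C(c3ccc(F)cc3)c3ccc(F)cc3)sc2CC(=O)O)ccn1` has not yet been measured in this assay. It differs from compound 3 in one place: 2-methylpyridin-4-yl in place of 1H-pyrazol-4-yl on an aromatic carbon. All three measured steps change the group on this same aromatic carbon of the shared core, so all three bear on the question. Both six-membered rings measured so far gave lower maximal responses than the 1H-pyrazol-4-yl of compound 3, by a modest margin for compound 2 and a large one for compound 1. Compound 4 carries a six-membered ring without a hydrogen-bond donor, so its maximal response is expected to fall below that of compound 3, by a modest step of a number 30 percentage points lower from compound 3 to compound 4 (beyond the scatter). Compound 4 is therefore estimated at 50%, with a range from 30% to 75%.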

Compound 4, largest response reached (reported as efficacy), in percent of the reference or control that the assay uses: 80%
Estimate against measurement, compound 4: 30 percentage points below; the measured number lies above the stated range.
By their numbers in this assay, from the lowest: compound 1; then compound 2; then compounds 3 and 4 (each within the scatter of the next).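

In this assay, 2-methylpyridin-4-yl in place of 1H-pyrazol-4-yl gives no change at the digits printed from compound 3 to compound 4 (within the scatter), so at this aromatic carbon neither the five-membered ring nor the hydrogen-bond donor of the 1H-pyrazol-4-yl is needed to reach the top of the numbers shown. The six-membered aromatic rings also do not share one level, with a number 25 percentage points higher from compound 2 to compound 4 (beyond the scatter) and a number 50 percentage points higher from compound 1 to compound 4 (beyond the scatter), so ring size alone does not sort the compounds: compounds 1 and 2 stand against any rule that a six-membered ring here gives a lower number. Nothing measured here accounts for these differences between the groups.

The compounds shown leave open what the methyl of 2-methylpyridin-4-yl contributes and whether the ring nitrogen matters, which a plain pyridin-4-yl or an unsubstituted phenyl on the same carbon would help to separate. They also leave open how the number would respond if that methyl gave way to a methoxy group, an aminomethyl group or a longer alkyl chain.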